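Swapping the aminoacyl group on a sulfamoyl adenosine analogue

The source may report more compounds than this note shows. Statements on the series, on what has been measured and on what is new or still open speak of the compounds shown alone.

Compound 1 `Nc1ncnc2c1ncn2[C@@H]1CO[C@H](COS(=O)(=O)NC(=O)[C@@H]2CCCN2)[C@@H](O)C1` gives 2800 nM in a functional assay on PBMC cells (Homo sapiens) for inhibition (a higher number here means a weaker inhibitor, a lower number a stronger inhibitor), the higher of the two numbers seen. Compound 2 `Nc1ncnc2c1ncn2[C@@H]1CO[C@H](COS(=O)(=O)NC(=O)[C@@H]2CCCN2)[C@@H](O)[C@H]1O` gives 750 nM in this assay, and the step of a 3.7-fold lower number from compound 1 to compound 2 (0.57 log units; beyond the scatter) covers only a change on the saturated ring of the core. Compound 3 `CC(C)C[C@H](N)C(=O)NS(=O)(=O)OC[C@H]1OC[C@@H](n2cnc3c(N)ncnc32)C[C@@H]1O` differs from compound 1 by 1-amino-3-methylbutyl in place of pyrrolidin-2-yl on a carbonyl carbon. Among the measured compounds shown here, no measured step touches this carbonyl-side change, so the direction is open and the estimate is wide. Compound 3 is expected to give 3000 nM (range 500 nM to 20000 nM), a step of a 1.1-fold higher number from compound 1 to compound 3 (0.03 log units; within the scatter) that is expected.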

Compound 3, half-maximal inhibitory concentration: 6800 nM
The estimate for compound 3 lay 2.3-fold (0.36 log units) below the measured number, within the range that was stated.
By their numbers in this assay, from the lowest: compound 2; then compound 1; then compound 3.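

The carbonyl-side position responds to the group it carries: in this assay, 1-amino-3-methylbutyl in place of pyrrolidin-2-yl gives a 2.4-fold higher number from compound 1 to compound 3 (0.39 log units; beyond the scatter), so the number moves with this change as well as with the change on the saturated ring. This one step removes the ring and adds a heavy atom together, and it cannot separate the two. No evidence is available that accounts for the shift. On these data alone, it remains open whether hydroxy on the saturated ring carbon lowers the number equally when 1-amino-3-methylbutyl is present. As far as these compounds go, how a shorter chain such as 1-aminoethyl would read also remains open.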